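A Dichlorophenyl Replacement on a Urea Already at the Limit

A few compounds are considered here, and "the series" means these few. Any claim that something is new, unique, unknown or untested is made for them only; others in the source may bear on it.

Compound 1 `O=C(Nc1cccc(-n2cc(-c3ccncc3)c(-c3ccc(Cl)c(O)c3)n2)c1)Nc1cccc(C(F)(F)F)c1` was examined in a functional assay on MOLT-4 cells (Homo sapiens) for inhibition, read by sulforhodamine B assay, with a stated time of 48 h; a lower number here means that less compound is tolerated, a higher number that more compound is tolerated. In this assay compound 1 gives > 32500 nM, which is a limit of the assay rather than a number (the limit of > 32500 nM in this assay, at which 1 of the 2 values shown sits). Compound 2 `COc1cc(-c2nn(-c3cccc(NC(=O)Nc4cc(C(F)(F)F)cc(C(F)(F)F)c4)c3)cc2-c2ccncc2)ccc1Cl` was examined in the same way. In this assay compound 2 gives > 50000 nM, again a limit and not a number (the limit of > 50000 nM in this assay, at which 1 of the 2 values shown sits). Among the compounds with values here, compound 1 therefore stands only at a limit, and the one further value shown is also a limit, so no order between the two can be drawn. Compound 3 `O=C(Nc1cccc(-n2cc(-c3ccncc3)c(-c3ccc(Cl)c(O)c3)n2)c1)Nc1ccc(Cl)c(Cl)c1` differs from compound 1 in one place: 3,4-dichlorophenyl in place of 3-(trifluoromethyl)phenyl on an amide-type nitrogen. Within the data shown here, no measured step covers such a change. With both reference values sitting at limits, the expected step is a step that the limit leaves unreadable from compound 1 to compound 3, none beyond the usual scatter. Compound 3 is accordingly estimated at about 40000 nM in this assay, with a range from 15000 nM to 100000 nM, and most likely reported once more only as a limit.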

Compound 3, concentration lethal to 50% of the cells: > 32500 nM
Compound 3: no number, only a limit; the forecaster's own chance of this, stated with the estimate: 75%; the middle value does not contradict the limit.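

Compound 3, like compound 1, is reported only as a limit and not as a number, so no step between the two can be read: the limit of > 32500 nM in this assay, at which 2 of the 3 values shown sit.

The compounds shown leave open whether 3,4-dichlorophenyl and 3-(trifluoromethyl)phenyl on an amide-type nitrogen differ at all in this assay.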